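The source may hold more compounds than are shown below. What is called first, only, known or untested is meant among the compounds shown, and "the series" means these compounds.

Measured so far in an ADME assay on HEK-293T cells (Homo sapiens) for cytotoxicity, read by CCK-8 assay, with a stated time of 48 h; a lower number here means a stronger inhibitor, a higher number a weaker inhibitor:
Compound 1 `COc1cccc(NC(=O)NCCNS(=O)(=O)c2ccc(-c3ccccc3OCc3ccccc3)s2)c1` — a limit only.
Compound 2 `O=[N+]([O-])c1ccc(NC(=S)NCCNS(=O)(=O)c2ccc(-c3ccccc3OCc3ccccc3)s2)cc1` — 8900 nM.
Compound 3 `O=C(NCCNS(=O)(=O)c1ccc(-c2ccccc2OCc2ccccc2)s1)Nc1cccc([N+](=O)[O-])c1` — 13300 nM.

For compound 1 the assay gives no number but a limit, > 20000 nM; this is the limit of > 20000 nM in this assay, at which 1 of the 3 values shown sits. Compound 2 has the lowest of the two numbers, yet its nearest neighbour compound 3 sits within the usual scatter, as the step of a 1.5-fold higher number from compound 2 to compound 3 (0.17 log units; within the scatter) shows, so no order between them can be claimed. The steps of an at least 2.2-fold lower number from compound 1 to compound 2 (0.35 log units; beyond the scatter) and an at least 1.5-fold lower number from compound 1 to compound 3 (0.17 log units; that floor lies within the scatter) both start from a limit.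

Compound 4 `O=[N+]([O-])c1ccc(NC(=S)NCCNS(=O)(=O)c2ccc(-c3ccccc3O[C@H]3CC[C@H](O)CC3)s2)cc1` differs from compound 2 at the other end of the molecule: 4-hydroxycyclohexyl in place of benzyl on an oxygen on an aromatic ring. None of the three measured steps touches this part; all of them exchange groups on the amine nitrogen of the urea or thiourea, far from the oxygen on the aromatic ring. They therefore give no direct guide to the size or direction of the change in this assay. For the measured compounds named here, with no comparable step in the set, the expectation for compound 4 is a step of about a 1.3-fold higher number from compound 2 to compound 4 (0.13 log units; within the scatter), which lies within the scatter, and an estimated value of 12000 nM, with a range from 5000 nM to 30000 nM; a limit rather than a number is also possible.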

Compound 4, half-maximal inhibitory concentration: 10500 nM
For compound 4 the middle estimate is 1.1-fold (0.06 log units) above the measured one, and the stated range covers the measured number.
By their numbers in this assay, from the lowest: compounds 2, 4 and 3 (each within the scatter of the next). At a limit, above all of these: compound 1.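

The step of a 1.2-fold higher number from compound 2 to compound 4 (0.07 log units; within the scatter) in this assay is the only one shown at the oxygen on the aromatic ring, so it extends the picture beyond the exchanges on the amine nitrogen. At this position, benzyl gives way to 4-hydroxycyclohexyl, which replaces the aromatic ring with a non-aromatic one and brings in a hydrogen-bond donor, a hydrogen-bond acceptor and defined stereocentres, yet the two compounds cannot be told apart in this read-out. The data shown offer no explanation for this outcome.

A single exchange cannot show whether this position tolerates change in general, and a basic amine such as an aminoethyl chain or a carboxylic acid on this oxygen could behave differently. On these data alone, it also remains open whether 4-hydroxycyclohexyl would give a similar result on the urea of compound 3, and whether the other stereoisomer of the 4-hydroxycyclohexyl group would match compound 4.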